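The source may report more compounds than this note shows. Statements on the series, on what has been measured and on what is new or still open speak of the compounds shown alone.

Of the compounds shown here, two have so far been tested in a functional assay on MCF7 cells (Homo sapiens) for antiproliferative activity, read by MTT assay, with a stated time of 72 h; on this read-out higher numbers stand for weaker inhibition and lower numbers for stronger inhibition. Compound 1 `COc1cccc(N2C(=O)COc3ccc(-c4cnc(Cl)c(NS(=O)(=O)c5ccc(F)cc5)c4)cc32)c1` carries a methoxy on one of its outer aromatic rings. In this assay compound 1 gives > 40000 nM, which is a limit of the assay rather than a number. Compound 2 `O=C1COc2ccc(-c3cnc4ccccc4c3)cc2N1c1ccc(F)cc1` shares the same core but has a different outer part. In this assay compound 2 gives > 40000 nM, again a limit and not a number. For the measured compounds named here, both results sit at the limit of > 40000 nM in this assay, at which 2 of the 2 values shown sit, so no compound can be ranked against the other and no step between measured compounds is available.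

Compound 3 `O=C1COc2ccc(-c3cnc(Cl)c(NS(=O)(=O)c4ccc(F)cc4)c3)cc2N1c1ccccc1` is the next compound to be measured. It differs from compound 1 in one place: hydrogen in place of methoxy on an aromatic carbon. The rest of compound 1 stays untouched, so that 3-methoxyphenyl becomes phenyl. The estimated step is a number no higher from compound 1 to compound 3 (the limit leaves the size open), with no direction beyond the scatter, because the starting point sits at the limit of > 40000 nM in this assay, at which 2 of the 2 values shown sit. Compound 3 is therefore expected to give about 40000 nM in this assay, within an estimated range from 15000 nM to 100000 nM, and most likely only another limit.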

Compound 3, half-maximal inhibitory concentration: > 40000 nM
Compound 3 was reported as a limit (the forecaster's own chance of this, stated with the estimate: 75%); the middle value sits exactly at the limit.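

Compound 1 and compound 3 are both reported as a limit of the assay rather than as a number, so no step can be read from compound 1 to compound 3: the limit of > 40000 nM in this assay, at which 3 of the 3 values shown sit.

The compounds shown leave open whether swapping 3-methoxyphenyl for phenyl changes anything in this assay, and which structure would give a measurable number there.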